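Ester for tert-butyl on the phenyl arm

A few compounds are considered here, and "the series" means these few. Any claim that something is new, unique, unknown or untested is made for them only; others in the source may bear on it.

Compound 1 `COc1cc(-c2ccnc3cc(-c4ccc5cc[nH]c5c4)nn23)cc(OC)c1OC` gives 187 nM in a functional assay on HCT-116 cells (Homo sapiens) for inhibition, read by CCK-8 assay, with a stated time of 48 h; a higher number here means a weaker inhibitor, a lower number a stronger inhibitor. Compound 3 `COc1cc(-c2ccnc3cc(-c4ccc5ccn(C)c5c4)nn23)cc(OC)c1OC` gives 1040 nM in this assay, and the step of a 5.6-fold higher number from compound 1 to compound 3 (0.75 log units; beyond the scatter) is modest. Compound 2 `COc1cc(-c2ccnc3cc(-c4ccc(C(C)(C)C)cc4)nn23)cc(OC)c1OC` reaches only a limit of this assay, > 10000 nM, so its number is a limit and not a value (the limit of > 10000 nM in this assay, at which 1 of the 3 values shown sits). The steps of an at least 53-fold higher number from compound 1 to compound 2 (1.72 log units; beyond the scatter) and an at least 9.6-fold lower number from compound 2 to compound 3 (0.98 log units; beyond the scatter) place compound 2 at the weak end of the three. Compound 4 `CCOC(=O)c1ccc(-c2cc3nccc(-c4cc(OC)c(OC)c(OC)c4)n3n2)cc1` differs from compound 2 by ethoxycarbonyl in place of tert-butyl on an aromatic carbon. Within the data shown here, no measured step alters a group on that phenyl ring, so there is no direct guide, and the losses from both indoles to compound 2 give no ground to expect an ester to recover much. Compound 4 is therefore expected to stay near the limit, with an at least 1.2-fold lower number from compound 2 to compound 4 (0.09 log units; that floor lies within the scatter) as the expected step. The estimate for compound 4 is 8000 nM, with a range from 1500 nM to 40000 nM.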

Compound 4, half-maximal inhibitory concentration: > 10000 nM
Compound 4: no number, only a limit; the forecaster's own chance of this, stated with the estimate: 55%; at least 1.2-fold (0.09 log units) between middle value and limit.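

Compound 2 and compound 4 both stand at a limit in this assay, so no step between them can be read: the limit of > 10000 nM in this assay, at which 2 of the 4 values shown sit.

The compounds shown leave open how ethoxycarbonyl and tert-butyl truly compare on that phenyl ring.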